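A few compounds are considered here, and "the series" means these few. Any claim that something is new, unique, unknown or untested is made for them only; others in the source may bear on it.

Measured in an assay on isolated protein for inhibition of cathepsin S (Homo sapiens), read by fluorescence, with a stated time of 20 min; on this read-out lower numbers stand for stronger inhibition and higher numbers for weaker inhibition:
compound 1 `CC(C)(C#N)NC(=O)[C@@H]1C[C@@H](S(=O)(=O)c2ccccc2)C[C@H]1C(=O)N1CCOCC1`, 3 nM
compound 2 `C[C@@H]1CN(C(=O)[C@@H]2C[C@H](S(=O)(=O)c3ccccc3)C[C@H]2C(=O)NC2(C#N)CC2)C[C@H](C)O1`, 0.4 nM
compound 3 `CN1CCN(C(=O)[C@@H]2C[C@H](S(=O)(=O)c3ccccc3)C[C@H]2C(=O)NC2(C#N)CC2)CC1`, 2 nM

Compound 2 gives the lowest number of the three, with compound 3 nearest and compound 1 furthest, both gaps beyond the scatter. Compound 4 `N#CC1(NC(=O)[C@@H]2C[C@@H](S(=O)(=O)c3ccccc3)C[C@H]2C(=O)N2CCNCC2)CC1` is not yet measured; it differs from compound 2 in one place: piperazin-1-yl in place of 2,6-dimethylmorpholin-4-yl on a carbonyl carbon. Among the measured compounds shown here, the one measured step that bears on this place is a 5.0-fold higher number from compound 2 to compound 3 (0.70 log units; beyond the scatter), which altered the same group at the same carbonyl carbon. A step of similar size and the same direction is therefore expected in this assay, namely a 5.0-fold higher number from compound 2 to compound 4 (0.70 log units; beyond the scatter). Compound 4 is estimated at 2 nM, with a range from 0.6 nM to 6 nM.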

Compound 4, half-maximal inhibitory concentration: 11 nM
The estimate for compound 4 lay 5.5-fold (0.74 log units) below the measured number; measured number above the stated range.
By their numbers in this assay, from the lowest: compound 2; then compounds 3 and 1 (each within the scatter of the next); then compound 4.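

In this assay, the substituent on the carbonyl carbon responds to a change as small as hydrogen in place of methyl on an amine nitrogen in a ring, with a 5.5-fold higher number from compound 3 to compound 4 (0.74 log units; beyond the scatter) for that single change. Replacing 2,6-dimethylmorpholin-4-yl with piperazin-1-yl therefore gives a 28-fold higher number from compound 2 to compound 4 (1.44 log units; beyond the scatter) as its step, larger than a 5.0-fold higher number from compound 2 to compound 3 (0.70 log units; beyond the scatter) for the methylated ring. The group on that ring nitrogen thus accounts for part of the difference at this position.

Open, going by these compounds, is how an ethyl or acetyl group on that nitrogen would read, and how unsubstituted morpholin-4-yl would compare with compound 2 on the same core. Nothing available explains the size of these steps.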